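The compounds below may be only part of what the source reports. "The series", "measured", "known", "first", "only" and "open" are said of these compounds alone.

In a functional assay on SK-OV-3 cells (Homo sapiens) for cytotoxicity, read by spectrophotometry, with a stated time of 72 h (a higher number here means a weaker inhibitor, a lower number a stronger inhibitor), compound 3 `COc1ccc(-n2c(-c3cc(OC)c(OC)c(OC)c3)cccc2=O)cc1O` gives 1220 nM. Compound 1 `COc1cc(-n2c(-c3ccncc3)cccc2=O)cc(OC)c1OC` gives 1790 nM, within the scatter of compound 3, so the two stand level. Compound 2 `COc1ccc(-n2c(-c3cc(OC)c(OC)c(OC)c3)cccc2=O)cc1OCc1ccccc1` gives 25500 nM, a much higher number. Compound 4 `COc1ccc(-n2c(-c3cc(OC)c(OC)c(OC)c3)cccc2=O)cc1OC` has not yet been measured and differs from compound 3 by methyl in place of hydrogen on an oxygen on an aromatic ring, that is, hydroxy to methoxy. For the measured compounds named here, only one measured step bears on this oxygen: a 21-fold lower number from compound 2 to compound 3 (1.32 log units; beyond the scatter), a large step with hydrogen in place of benzyl. Going by the values given here, compound 1 offers no matched step here. Benzyl on that oxygen goes with the much higher number, while methyl there remains untested. A higher number in this assay is therefore expected, but a far smaller rise than the benzyl step, and a result within the scatter cannot be ruled out. The expected step is a 2.0-fold higher number from compound 3 to compound 4 (0.31 log units; beyond the scatter). For compound 4 the estimated value is 2500 nM, with an expected range of 700 nM to 9000 nM.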

Compound 4, half-maximal inhibitory concentration: 14300 nM
The estimate for compound 4 lay 5.7-fold (0.76 log units) below the measured number, and the stated range ends below it.
By their numbers in this assay, from the lowest: compounds 3 and 1 (each within the scatter of the next); then compounds 4 and 2 (each within the scatter of the next).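

In this assay the smallest possible change on this oxygen, hydroxy to methoxy, gives a 12-fold higher number from compound 3 to compound 4 (1.07 log units; beyond the scatter) and so shows that the hydrogen matters in its own right, not only when benzyl takes its place. Methyl and benzyl stand level, with a 1.8-fold lower number from compound 2 to compound 4 (0.25 log units; within the scatter) as the step between them, so among compounds 2, 3 and 4 what separates the numbers is whether the oxygen keeps its hydrogen, not which of these two groups sits on it. No measurement at hand gives a reason for this.

On these data alone, whether an amine in place of the hydroxy would keep the number of compound 3 stays open. So does whether an acetyl group on this oxygen would stand with methyl and benzyl.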